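This account rests on a few compounds, and the source may have more. Where it says the series, first, only, none or still open, it means among the compounds named here.

Compound 1 `Clc1ccc(/C=N/Nc2nc3ccccc3s2)cc1` was examined in a functional assay on HCT-8 cells (Homo sapiens) for cytotoxicity, read by MTT assay, with a stated time of 72 h; a lower number here means a stronger inhibitor, a higher number a weaker inhibitor. In this assay compound 1 gives > 17300 nM, which is a limit of the assay and not a number. Two relatives share its core. Compound 2 `O=C(O)c1ccccc1/C=N/Nc1nc2ccccc2s1` gives > 16800 nM in this assay, again a limit. Compound 3 `Clc1ccc(/C=N/Nc2nc3ccccc3s2)c(Cl)c1` gives > 15500 nM in this assay, also a limit. Because every value sits at such a limit (the limit of > 15500 nM in this assay, at which 1 of the 3 values shown sits, (the limit of > 16800 nM in this assay, at which 1 of the 3 values shown sits), (the limit of > 17300 nM in this assay, at which 1 of the 3 values shown sits)), compound 1 cannot be ranked among its relatives; all three are simply unresolved. Going by the values given here, the single one-place step, a step that the two limits leave unreadable from compound 1 to compound 3, puts chloro in place of hydrogen on an aromatic carbon and cannot be read in size. Compound 4 `Brc1ccc(/C=N/Nc2nc3ccccc3s2)cc1` has not yet been measured. It differs from compound 1 by bromo in place of chloro on an aromatic carbon. Among the compounds with values here, no measured step bears on swapping one halogen for another, and the only step at hand is unreadable, so no shift beyond the scatter is expected. Compound 4 is therefore expected to give about 20000 nM in this assay, within a range from 6000 nM to 60000 nM, most likely as another limit. The step that the limit leaves unreadable from compound 1 to compound 4 is expected to be negligible.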

Compound 4, half-maximal inhibitory concentration: > 15000 nM
Compound 4 gave a limit, no number (the forecaster's own chance of this, stated with the estimate: 80%); the middle value is on the limit's open side.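

The step from compound 1 to compound 4, bromo in place of chloro, cannot be read in this assay: both values are limits of the assay and not numbers. The compounds shown leave open how these four rank and whether any change to the shared core yields a number.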